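The source may hold more compounds than are shown below. What is called first, only, known or untested is meant among the compounds shown, and "the series" means these compounds.

Among the measured compounds shown here, compound 2 `O=C1C[C@H]2O[C@H]([C@H](O)c3ccccc3)[C@H](O)[C@H]2O1` is one of three compounds so far measured in a functional assay on Raji cells (Homo sapiens) for antiproliferative activity, read by MTT assay, with a stated time of 72 h; on this read-out lower numbers stand for stronger inhibition and higher numbers for weaker inhibition. In this assay compound 2 gives 18500 nM, the highest of the three numbers. For the measured compounds named here, compound 3 `O=C1C[C@@H]2O[C@H]3[C@H](c4ccccc4)c4ccccc4CO[C@H]3[C@@H]2O1` gives 15900 nM, a number that lies within the usual scatter of the one for compound 2, so the two cannot be told apart. Compound 1 `O=C1C[C@@H]2O[C@@H](Cc3ccccc3)[C@@H](O)[C@@H]2O1` gives 30 nM, far lower than the number for compound 2, a gap well beyond the scatter. No two of these compounds differ in only one place, so no single step between measured compounds can be read off.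

Compound 4 `Cc1ccccc1[C@H](c1ccccc1)[C@H]1O[C@@H]2CC(=O)O[C@@H]2[C@H]1O` has not yet been measured in this assay. It differs from compound 2 by 2-methylphenyl in place of hydroxy on a saturated chain carbon bound to an aromatic carbon and a saturated ring carbon. Two things about the measured compounds bear on this change. Compound 1, whose structure holds no hydroxy of this kind, gives 30 nM, the low number of the set. Compound 3, whose structure holds two aromatic rings, gives 15900 nM, a high number. Compound 4 loses the hydroxy but gains a second aromatic ring, so its expected value sits between those two outcomes. The step from compound 2 to compound 4 is expected to be a 9.3-fold lower number from compound 2 to compound 4 (0.97 log units; beyond the scatter), a fall in the number beyond the scatter. For compound 4 the estimated value is 2000 nM, with a range from 200 nM to 20000 nM.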

Compound 4, half-maximal inhibitory concentration: 5670 nM
Beside the measured number, compound 4's estimate is 2.8-fold (0.45 log units) below it; low and high end bracket the measured number.
By their numbers in this assay, from the lowest: compound 1; then compound 4; then compounds 3 and 2 (each within the scatter of the next).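

In this assay, among the compounds shown here, the swap of hydroxy for 2-methylphenyl on a saturated chain carbon bound to an aromatic carbon and a saturated ring carbon gives a 3.3-fold lower number from compound 2 to compound 4 (0.51 log units; beyond the scatter), and this is the first step in the set that isolates a change in one place. It shows that this carbon can carry a far larger group, with seven heavy atoms and a whole aromatic ring in place of a single oxygen, and that the number still falls rather than rises. It also shows that the hydroxy, with its hydrogen-bond donor and acceptor, is not needed on this carbon for a number of this size, while nothing at hand explains why the number moves as it does.

The single step joins two events, the loss of the hydroxy and the arrival of the aromatic ring, and the compounds shown cannot separate them. A methyl or an amine on this carbon, or a phenyl without its methyl, would show which of the two events matters and whether the methyl on the new ring plays any part.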